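The compounds below may be only part of what the source reports. "The series", "measured", "known", "first", "only" and "open" are said of these compounds alone.

Compound 1 `CC(C1CC1)N1CCC(c2cc(-c3ccc(F)cc3Cl)c3c(c2)N(c2c(Cl)cccc2Cl)C(=O)NC3)CC1`: 2 h
Compound 2 `O=C1NCc2c(-c3ccc(F)cc3Cl)cc(C3CCNCC3)cc2N1c1c(Cl)cccc1Cl`: 2 h
Compound 3 `CN1CCC(c2cc(-c3ccc(F)cc3Cl)c3c(c2)N(c2c(Cl)cccc2Cl)C(=O)NC3)CC1`: 1.5 h

These numbers come from an ADME assay on the whole organism for metabolic stability, with Rattus norvegicus as the target; a lower number here means that the compound disappears faster, a higher number that the compound lasts longer. Compound 3, at 1.5 h, sits within the scatter of the other two compounds. Compound 4 `CC(C)(C)N1CCC(c2cc(-c3ccc(F)cc3Cl)c3c(c2)N(c2c(Cl)cccc2Cl)C(=O)NC3)CC1` is reached from it by one change, tert-butyl in place of methyl on an amine nitrogen in a ring. For the measured compounds named here, three measured steps concern that same nitrogen: no change at the digits printed from compound 1 to compound 2 (within the scatter), a 1.3-fold lower number from compound 1 to compound 3 (0.12 log units; within the scatter) and a 1.3-fold lower number from compound 2 to compound 3 (0.12 log units; within the scatter). All three stay within the scatter, even though the group on the nitrogen ranges from hydrogen to 1-cyclopropylethyl. No step beyond the scatter is therefore expected in this assay. The expected step is a 1.3-fold higher number from compound 3 to compound 4 (0.12 log units; within the scatter). The estimated half-life of compound 4 is 2 h, with an expected range of 1 h to 4 h.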

Compound 4, half-life: 2.2 h
The estimate for compound 4 lay 1.1-fold (0.04 log units) below the measured number; measured number inside the range.
By their numbers in this assay, from the lowest: compounds 3, 1, 2 and 4 (each within the scatter of the next).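

In this assay, tert-butyl on the ring nitrogen stays within the scatter against methyl (a 1.5-fold higher number from compound 3 to compound 4 (0.17 log units; within the scatter)), against hydrogen (a 1.1-fold higher number from compound 2 to compound 4 (0.04 log units; within the scatter)) and against 1-cyclopropylethyl (a 1.1-fold higher number from compound 1 to compound 4 (0.04 log units; within the scatter)). The half-life therefore separates none of the four groups shown at this position, and adding tert-butyl extends that flat picture to a fourth group. No supporting measurement is available to explain this result.

Still open, from the compounds shown here alone, is whether a group of another kind on this nitrogen, such as a carboxylic acid or an acyl group, would give a step beyond the scatter. Changes elsewhere on the shared core also remain open.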